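The source may hold more compounds than are shown below. What is called first, only, known or untested is meant among the compounds shown, and "the series" means these compounds.

Compound 2 `Cc1cc(C)c(-n2c(Cl)cn3c(CN(CCC4CC4)CCC(F)(F)F)c(C(F)(F)F)nc23)c(C)c1` gives the highest of the two numbers seen so far: in an assay on cells for displacement of a labelled ligand from corticotropin-releasing factor receptor 1 (Homo sapiens), with a stated time of 100 min (on this read-out higher numbers stand for weaker inhibition and lower numbers for stronger inhibition), compound 2 gives 110 nM, while compound 1 `CCN(CCC1CC1)Cc1c(C(F)(F)F)nc2n(-c3c(C)cc(C)cc3C)c(Cl)cn12` gives 13 nM, the move being an 8.5-fold higher number from compound 1 to compound 2 (0.93 log units; beyond the scatter). Compound 3 `Cc1cc(C)c(-n2c(Cl)cn3c(CN(CCC(F)(F)F)Cc4ccc(Cl)cc4)c(C(F)(F)F)nc23)c(C)c1` differs from compound 2 by 4-chlorophenyl in place of cyclopropylmethyl on a saturated chain carbon bound to an amine nitrogen. Among the measured compounds shown here, no measured step bears on this exchange; the one step known, an 8.5-fold higher number from compound 1 to compound 2 (0.93 log units; beyond the scatter), concerns another place on the chain. With nothing to lean on, compound 3 is expected to change by a 1.2-fold lower number from compound 2 to compound 3 (0.09 log units; within the scatter), within the scatter. Compound 3 is estimated at 90 nM, between 20 nM and 400 nM.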

Compound 3, inhibition constant: 12 nM
Compound 3: middle estimate off by 7.5-fold (0.88 log units), on the high side, outside the stated range (below it).
By their numbers in this assay, from the lowest: compounds 3 and 1 (each within the scatter of the next); then compound 2.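

The exchange on a saturated chain carbon bound to an amine nitrogen gives a 9.2-fold lower number from compound 2 to compound 3 (0.96 log units; beyond the scatter), so this position strongly affects the number in this assay and takes an aromatic ring in place of cyclopropylmethyl without loss. Among the compounds shown here, the single change alters ring size, aromatic character and chlorine together, so these cannot be separated. Nothing measured here accounts for the step. On these data alone, whether the chlorine matters remains open, as a plain phenyl or a 4-methoxyphenyl would show. Also open, as far as these compounds go, is how 4-chlorophenyl behaves when the chain lacks the trifluoromethyl.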